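Series notes: from compound 1 to compound 3

A few compounds are considered here, and "the series" means these few. Any claim that something is new, unique, unknown or untested is made for them only; others in the source may bear on it.

Measured so far:
compound 1 `NS(=O)(=O)c1ccc(-n2nc(-c3ccc(Cl)cc3)cc2-c2cc(O)ccc2O)cc1`: 35500 nM
compound 2 `CC(=O)NS(=O)(=O)c1ccc(-n2nc(-c3ccc(Cl)cc3)cc2-c2cc(O)ccc2O)cc1`: 93900 nM

In a functional assay on cells (Cancer cell lines, Homo sapiens) for cytotoxicity, read by sulforhodamine B assay, with a stated time of 48 h (a lower number here means a stronger inhibitor of growth, a higher number a weaker inhibitor of growth), compound 1 gives 35500 nM, the lower of the two numbers; compound 2 gives 93900 nM. Among the compounds with values here, the only measured step, a 2.6-fold higher number from compound 1 to compound 2 (0.42 log units; beyond the scatter), is a change at the sulfonamide nitrogen and leaves the rest of the shared core untouched.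

Compound 3 `NS(=O)(=O)c1ccc(-n2nc(-c3ccc(Cl)cc3)cc2C2=CC(=O)C=CC2=O)cc1` differs from compound 1 in another place: a group of 8 heavy atoms (6 carbon, 2 oxygen; one six-membered non-aromatic ring of carbon only) in place of a group of 8 heavy atoms (6 carbon, 2 oxygen; one six-membered aromatic ring of carbon only), on an aromatic carbon. Within the data shown here, no measured step touches this group, so the step from compound 1 to compound 2 gives no guidance on its size or direction; the change is treated as an unknown of moderate size around the number for compound 1.

For compound 3 the expected value in this assay is 30000 nM, within 8000 nM to 100000 nM, which means an expected step of a 1.2-fold lower number from compound 1 to compound 3 (0.07 log units; within the scatter).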

Compound 3, concentration for total growth inhibition: 53000 nM
Compound 3: middle estimate off by 1.8-fold (0.25 log units), on the low side, within the range that was stated.
By their numbers in this assay, from the lowest: compounds 1, 3 and 2 (each within the scatter of the next, the first and the last beyond it).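

In this assay, the exchange of the 2,5-dihydroxyphenyl group for the six-membered non-aromatic ring gives a 1.5-fold higher number from compound 1 to compound 3 (0.17 log units; within the scatter) and so leaves the number at this position within the scatter. The entering group has 0 hydrogen-bond donors where the leaving group has 2, so in this pair the loss of those donors comes with no step beyond the scatter. Nothing available here bears on the cause of this result.

On these data alone, whether a single hydroxyl, a methoxy group, an amine or a carboxylic acid on a ring at this place would move the number stays open. Also open, as far as these compounds go, is whether acetyl on the sulfonamide nitrogen would give a step of similar size and direction on the core of compound 3.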